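This account rests on a few compounds, and the source may have more. Where it says the series, first, only, none or still open, it means among the compounds named here.

Measured so far:
- compound 1 `COc1ccc(/C=C2/CN(C)/C(=N/c3ccc(C)cc3)S2)cc1`: 11100 nM
- compound 2 `COc1ccc(/C=C2\S/C(=N\c3ccc(Cl)cc3)N(C)C2=O)cc1`: 10400 nM

These values come from a functional assay on HCT-116 cells (Homo sapiens) for antiproliferative activity, read by MTT assay, with a stated time of 72 h; a lower number here means a stronger inhibitor, a higher number a weaker inhibitor. They lie within the scatter of each other, so compound 2 stands level with compound 1.

Compound 3 `COc1ccc(/C=C2\S/C(=N\c3ccc(Br)cc3)N(C)C2=O)cc1` carries bromo in place of chloro on an aromatic carbon, para to a large group, relative to compound 2: bromo in place of chloro on an aromatic carbon. For the measured compounds named here, no measured pair shows a change of this kind, so no shift beyond the scatter is expected in this assay. The expected change is small, a 1.1-fold lower number from compound 2 to compound 3 (0.04 log units; within the scatter). For compound 3 the estimated value is 9500 nM, with an expected range of 4000 nM to 22000 nM.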

Compound 3, half-maximal inhibitory concentration: 17000 nM
Compound 3: middle estimate off by 1.8-fold (0.25 log units), on the low side; measured number inside the range.
By their numbers in this assay, from the lowest: compounds 2, 1 and 3 (each within the scatter of the next).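

Bromo in place of chloro, on an aromatic carbon para to a large group, gives a 1.6-fold higher number from compound 2 to compound 3 (0.21 log units; within the scatter) in this assay, so the 4-chlorophenyl and 4-bromophenyl compounds stand level at this position. For the compounds shown here, this is the only single-place step so far, and it shows that this exchange of one halogen for the other leaves the number within the scatter. No independent measurement bears on this step.

On these data alone, whether an amine, a hydroxyl or a carboxylic acid at this position would move the number beyond the scatter stays open. Compound 1 differs from compound 2 in more than one place, so the separate contribution of each difference also remains unresolved.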